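The source may report more compounds than this note shows. Statements on the series, on what has been measured and on what is new or still open speak of the compounds shown alone.

Compound 1 `Cc1cc(Nc2nc(NCc3ccc(Cl)cc3)nc3ccccc23)n[nH]1` in an assay for inhibition of high affinity nerve growth factor receptor (Homo sapiens), read by HTRF, with a stated time of 30 min, in the presence of a further agent that is not named here (a higher number here means a weaker inhibitor, a lower number a stronger inhibitor), gives 380 nM. Compound 2 `Cc1cc(Nc2nc(NCc3ccc(Br)cc3)nc3ccccc23)n[nH]1` carries the change bromo in place of chloro on an aromatic carbon and in this assay compound 2 gives 180 nM; the step is a 2.1-fold lower number from compound 1 to compound 2 (0.32 log units; beyond the scatter). Compound 3 `Cc1cc(Nc2nc(NCc3ccc(F)cc3F)nc3cc(Cl)ccc23)n[nH]1` stands on a different core and the difference between the two cores is not broken down here; in this assay compound 3 gives 15 nM, the lowest number of the three, with compounds 2 and 1 both beyond the scatter above it. Compound 4 `Cc1cc(Nc2nc(NCc3ccc(F)cc3F)nc3cc(Br)ccc23)n[nH]1` carries the change (bromo in place of chloro on an aromatic carbon). This is the same kind of change as in compound 2, not the same: there the place was para to a large group on a ring of carbon only, here it is part of a fused or bridged system of two rings, meta and para to a fused ring. Resting on the direction of a 2.1-fold lower number from compound 1 to compound 2 (0.32 log units; beyond the scatter), a smaller step is expected for compound 4, a 1.4-fold lower number from compound 3 to compound 4 (0.13 log units; within the scatter). Compound 4 is estimated at 11 nM, expected between 5 nM and 25 nM.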

Compound 4, half-maximal inhibitory concentration: 53 nM
Compound 4: the middle estimate sits 4.8-fold (0.68 log units) below what was measured; the whole stated range lies below it.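

Bromo in place of chloro on an aromatic carbon does not carry over as a fixed effect in this assay: on the core of compound 3 the step is a 3.5-fold higher number from compound 3 to compound 4 (0.55 log units; beyond the scatter). Set beside the earlier step, the direction reverses: the same change on two cores in this assay, a 2.1-fold lower number (0.32 log units; beyond the scatter) from compound 1 to compound 2 and a 3.5-fold higher number (0.55 log units; beyond the scatter) from compound 3 to compound 4, 7.5-fold (0.87 log units) apart, beyond the scatter of two such steps The two pairs differ both in where the change sits and in the rest of the molecule, and they do not show which of these sets the direction of the step.

On these data alone, it remains open how an amine, a methoxy group or a nitrile would compare with chloro and bromo at the place on the fused system. As far as these compounds go, the effect of the same halogen change on the benzyl ring with the fluoro groups of compound 3 also remains open.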